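The source may report more compounds than this note shows. Statements on the series, on what has been measured and on what is new or still open speak of the compounds shown alone.

Measured compounds:
compound 1 `COc1ccc(NS(=O)(=O)/C=C/c2c(F)c(F)c(F)c(F)c2F)cc1[N+](=O)[O-]` — 100000 nM
compound 2 `COc1ccc(NS(=O)(=O)/C=C/c2cc(OC)c(OC)c(OC)c2)cc1` — 35000 nM
compound 3 `COc1ccc(NS(=O)(=O)/C=C/c2c(F)c(F)c(F)c(F)c2F)cc1` — 5000 nM

These three compounds were tested in a functional assay on K562 cells (Homo sapiens) for cytotoxicity, read by trypan blue exclusion, with a stated time of 96 h; a higher number here means a weaker inhibitor, a lower number a stronger inhibitor. Compound 3 gives 5000 nM, compound 2 gives 35000 nM, and compound 1 gives 100000 nM.

Compound 1 differs from compound 3 by a single change, (nitro in place of hydrogen on an aromatic carbon). This change carried the number a 20-fold higher number from compound 3 to compound 1 (1.30 log units; beyond the scatter). Among the compounds with values here, compound 2 and compound 3 share the sulfonamide-linked arrangement but differ in the ring bearing the vinyl group; the difference between the two cores is not broken down here, and the two values show only that compound 2 stands higher than compound 3 in this assay.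

Compound 4 `COc1ccc(NS(=O)(=O)/C=C/c2cc(OC)c(OC)c(OC)c2)cc1[N+](=O)[O-]` has not yet been measured. It stands to compound 2 as compound 1 stands to compound 3: the change is nitro in place of hydrogen on an aromatic carbon. The place of the change is described in the same words in both pairs, so the same change is made here on the core of compound 2. On the basis of the step from compound 3 to compound 1, a rise of similar size is expected from compound 2 to compound 4, that is a 4.3-fold higher number from compound 2 to compound 4 (0.63 log units; beyond the scatter). Since compound 2 already starts from a high number, the result may reach the upper edge of what this assay reports, so the estimate is wide and a limit rather than a number is a real possibility. Compound 4 is accordingly expected to give about 150000 nM in this assay, with a range of 40000 nM to 700000 nM.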

Compound 4, half-maximal inhibitory concentration: 75000 nM
Beside the measured number, compound 4's estimate is 2.0-fold (0.30 log units) above it; the range from low to high includes it.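

In this assay, placing the nitro group on the core of compound 2 gave a 2.1-fold higher number from compound 2 to compound 4 (0.33 log units; beyond the scatter) and so repeated the direction of the earlier step on the core of compound 3, though not its size. Set side by side, the two steps are clearly different in size: the same change on two cores in this assay, a 20-fold higher number (1.30 log units; beyond the scatter) from compound 3 to compound 1 and a 2.1-fold higher number (0.33 log units; beyond the scatter) from compound 2 to compound 4, 9.3-fold (0.97 log units) apart, beyond the scatter of two such steps. Within the data shown here, the two pairs therefore show that this change moved the number the same way on both cores, but that the size of the step on one core did not carry over to the other; with only two pairs, they do not show which feature of the cores accounts for the gap, and they offer no rule for predicting the size of the step on a further core.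

The compounds shown leave open whether an amine or a carboxylic acid in the place taken by the nitro group would move the number in the same direction or by a similar amount on these two cores. They also leave open how the nitro group would behave on a third core, which would show whether either of the two steps is the more typical one for this series.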